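The compounds below may be only part of what the source reports. "The series", "measured", "known", "first", "only" and "open" are said of these compounds alone.

Working notes on the series. In an assay on HEK293 cells for positive allosteric modulation of metabotropic glutamate receptor 5 (Homo sapiens), read by FLIPR (a higher number here means that more compound is needed for the effect, a lower number that less compound is needed), compound 1 `O=C(c1ccc(F)c(F)c1)N1CC(c2nc(-c3cccc(F)c3)no2)C1` gives 3200 nM. Compound 2 `COC1CCN(C(=O)N2CC(c3nc(-c4cccc(Cl)c4)no3)C2)CC1` returns only a limit in this assay, > 10000 nM. Compound 3 `Cc1ccc(S(=O)(=O)N2CC(c3nc(-c4cccc(C)c4)no3)C2)cc1` likewise returns only a limit, > 10000 nM. Compound 2 thus stands at the limit of > 10000 nM in this assay, at which 2 of the 3 values shown sit, with no number of its own to anchor a step. Among the measured compounds shown here, no pair of measured compounds differing in one place exists in this set. Compound 4 `O=C(C1CCCO1)N1CC(c2nc(-c3cccc(Cl)c3)no2)C1` differs from compound 2 by oxolan-2-yl in place of 4-methoxypiperidin-1-yl on a carbonyl carbon. With compound 2 at a limit, the direction of the step cannot be read from measured data; any move below the limit is expected to be small. Compound 4 is estimated at 8000 nM, range 2500 nM to 30000 nM. The expected step is an at least 1.2-fold lower number from compound 2 to compound 4 (0.09 log units; that floor lies within the scatter).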

Compound 4, half-maximal effective concentration: > 10000 nM
Compound 4 was reported as a limit (the forecaster's own chance of this, stated with the estimate: 50%); middle value at least 1.2-fold (0.09 log units) from the limit.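

Among the compounds shown here, compound 2 and compound 4 both return only a limit, so no step between them can be read: the limit of > 10000 nM in this assay, at which 3 of the 4 values shown sit. The compounds shown leave open whether oxolan-2-yl or 4-methoxypiperidin-1-yl on a carbonyl carbon gives the lower number.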